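Ester to Benzamide: Expected Cytotoxicity of Compound 3

This account rests on a few compounds, and the source may have more. Where it says the series, first, only, none or still open, it means among the compounds named here.

Compound 2 `O=C(OC1CCC(CN2CCN(c3cc(=O)c4cc(C(F)(F)F)cc([N+](=O)[O-])c4s3)CC2)CC1)c1ccc(F)cc1` carries a ((4-fluorophenyl)carbonyl)oxy group on a saturated ring carbon of a six-membered non-aromatic ring of carbon only. In an ADME assay on Vero cells (Chlorocebus sabaeus) for cytotoxicity, read by MTT assay, with a stated time of 48 h (a higher number here means a weaker inhibitor, a lower number a stronger inhibitor), compound 2 gives > 64 ug/mL, which is a limit of the assay and not a number. Its nearest measured relative, compound 1 `CC(C)S(=O)(=O)OC1CCC(CN2CCN(c3cc(=O)c4cc(C(F)(F)F)cc([N+](=O)[O-])c4s3)CC2)CC1`, bears isopropylsulfonyl where compound 2 bears (4-fluorophenyl)carbonyl on an oxygen on a saturated carbon. In this assay compound 1 gives > 64 ug/mL, again a limit rather than a number. The step that the two limits leave unreadable from compound 1 to compound 2 is therefore not readable. Among the compounds with values here, the only thing the numbers show is the limit of > 64 ug/mL in this assay, at which 2 of the 2 values shown sit.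

Compound 3 `O=C(NC1CCC(CN2CCN(c3cc(=O)c4cc(C(F)(F)F)cc([N+](=O)[O-])c4s3)CC2)CC1)c1ccccc1` differs from compound 2 in one place: benzamido in place of ((4-fluorophenyl)carbonyl)oxy on a saturated ring carbon. Within the data shown here, no measured step speaks to this change, and the single step that exists is unreadable, so the prior for compound 3 rests on the two limits alone. Compound 3 is expected to land at 80 ug/mL, with a range from 40 ug/mL to 200 ug/mL. This estimate means a step that the limit leaves unreadable from compound 2 to compound 3, which is expected to be no change beyond the scatter, most likely ending again at a limit.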

Compound 3, half-maximal inhibitory concentration: 44.3 ug/mL
The estimate for compound 3 lay 1.8-fold (0.26 log units) above the measured number; measured number inside the range.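

Within the data shown here, compound 3, with benzamido on the saturated ring carbon, gives 44.3 ug/mL in this assay, the first reading at this position that is a number and not a limit of the assay. Replacing either oxygen-linked group with benzamido gives an at least 1.4-fold lower number from compound 2 to compound 3 (0.15 log units; that floor lies within the scatter) and an at least 1.4-fold lower number from compound 1 to compound 3 (0.15 log units; that floor lies within the scatter), so the direction is shown, but only a floor is known for the size of each step, and neither floor clears the scatter. The step between compound 1 and compound 2 still cannot be read, as both sit at the limit: the limit of > 64 ug/mL in this assay, at which 2 of the 3 values shown sit.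

Compound 3 differs from compound 2 both in the link to the ring, where the amide hydrogen enters, and in the loss of fluorine from the aromatic ring, so the compounds shown do not separate these two parts of the change. Going by these compounds, whether a 4-fluorobenzamido group, a free amine or a carboxylic acid on the same saturated ring carbon would give a number in this assay, and how that number would compare with compound 3, stays open.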